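The compounds below may be only part of what the source reports. "The series", "measured", "known", "first", "only" and "open" are said of these compounds alone.

Measured so far in an ADME assay on MCF-10A cells (Homo sapiens) for cytotoxicity, read by sulforhodamine B assay, with a stated time of 48 h; on this read-out lower numbers stand for stronger inhibition of growth and higher numbers for weaker inhibition of growth:
- compound 1, `Cc1ccc2nc(/N=C3\C(=O)N(CN(C)C)c4cccc(Cl)c43)sc2c1`: 7020 nM
- compound 2, `Cc1ccc2nc(/N=C3\C(=O)N(CN4CCCCC4)c4cccc(Cl)c43)sc2c1`: 30200 nM
- compound 3, `CCN(CC)CN1C(=O)/C(=N\c2nc3ccc(C)cc3s2)c2ccccc21`: 20400 nM

Compound 3 stands second highest of the three numbers; its gap to compound 2 is within the scatter, while compound 1 gives a lower number beyond the scatter. Within the data shown here, the only measured step, a 4.3-fold higher number from compound 1 to compound 2 (0.63 log units; beyond the scatter), concerns the amine on the chain and not the ring.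

Compound 4, `CCN(CC)CN1C(=O)/C(=N\c2nc3ccc(C)cc3s2)c2c(Cl)cccc21`, differs from compound 3 by chloro in place of hydrogen on an aromatic carbon. Among the measured compounds shown here, no measured pair isolates this change: compounds 1 and 2 both carry the chloro, and the values of compounds 1 and 2 bracket that of compound 3 on either side. No step beyond the scatter is therefore expected in this assay; the estimated step is a 1.4-fold lower number from compound 3 to compound 4 (0.13 log units; within the scatter). For compound 4 the estimate is 15000 nM, with a range from 6000 nM to 40000 nM.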

Compound 4, concentration for 50% growth inhibition: 43900 nM
Compound 4: middle estimate off by 2.9-fold (0.47 log units), on the low side; the measured number lies above the stated range.
By their numbers in this assay, from the lowest: compound 1; then compounds 3, 2 and 4 (each within the scatter of the next, the first and the last beyond it).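

In this assay, the chloro on this aromatic carbon can now be read alone: a 2.2-fold higher number from compound 3 to compound 4 (0.33 log units; beyond the scatter) points to weaker inhibition of growth, a modest step. With the chloro in place, the chain amine still counts for diethylamino against dimethylamino, with a 6.3-fold higher number from compound 1 to compound 4 (0.80 log units; beyond the scatter) beyond the scatter, while a 1.5-fold higher number from compound 2 to compound 4 (0.16 log units; within the scatter) for diethylamino against piperidin-1-yl stays within it. No measurement given here explains the chloro step. Open, from the compounds shown here alone, is whether fluoro or methoxy on this carbon would give a similar step, and whether the chloro step holds with dimethylamino or piperidin-1-yl on the chain.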